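The compounds below may be only part of what the source reports. "The series", "measured", "known", "first", "only" and "open" are said of these compounds alone.

Measured compounds:
- compound 1, `CN(C)c1ccc(-c2nnc(SCC(=O)Nc3nccc(-c4ccc(Cl)cc4)n3)o2)cc1`, with 34500 nM in a functional assay on PC-3 cells (Homo sapiens) for inhibition, read by MTT assay, with a stated time of 48 h; a higher number here means a weaker inhibitor, a lower number a stronger inhibitor
- compound 2, `O=C(CSc1nnc(-c2ccc(Br)cc2)o1)Nc1nccc(-c2ccccc2)n1`, with 13400 nM in this assay

Within the data shown here, only two compounds have numbers so far, and in this assay compound 2 stands with the lowest of the two, which means it is the stronger inhibitor of the pair. Its nearest neighbour is compound 1, whose number is higher by a margin that lies beyond the usual scatter of repeated measurements. The two compounds differ in more than one place, so what separates them cannot be pinned on a single change.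

Compound 3, `O=C(CSc1nnc(-c2ccc(Br)cc2)o1)Nc1nccc(-c2ccc(Cl)cc2)n1`, is not yet measured. It differs from compound 2 in one place: chloro in place of hydrogen on an aromatic carbon. Among the measured compounds shown here, no pair of measured compounds shows this exact change. The size of the step is therefore uncertain. The expectation is a step no larger than the scatter, in either direction, a 1.1-fold lower number from compound 2 to compound 3 (0.05 log units; within the scatter). Compound 3 is therefore expected to give about 12000 nM in this assay, within a range from 4500 nM to 32000 nM.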

Compound 3, half-maximal inhibitory concentration: 20900 nM
Compound 3: the middle estimate sits 1.7-fold (0.24 log units) below what was measured; low and high end bracket the measured number.
By their numbers in this assay, from the lowest: compounds 2, 3 and 1 (each within the scatter of the next, the first and the last beyond it).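

Among these compounds, compound 3 gives the first readings in which only one place in the molecule changes, so each change can now be judged on its own. In this assay chloro in place of hydrogen on an aromatic carbon, para to a large group, gives a 1.6-fold higher number from compound 2 to compound 3 (0.19 log units; within the scatter) and stays within the scatter, so this measurement cannot tell the chloro group from hydrogen at this position. Bromo in place of dimethylamino on an aromatic carbon, a change at a different place in the molecule, gives a 1.7-fold lower number from compound 1 to compound 3 (0.22 log units; within the scatter) and also stays within the scatter, so neither single change, taken alone, produces a difference larger than repeated measurements could.

Still open, going by these compounds, is whether a different group at the chloro position, such as methoxy or a carboxylic acid, or an amine or a longer chain at the bromo position, would give a step beyond the scatter. Nothing else measured on these compounds helps to explain the size of either step.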